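Shrinking the Ring on One Amine Nitrogen

The source may report more compounds than this note shows. Statements on the series, on what has been measured and on what is new or still open speak of the compounds shown alone.

Compound 1 `C1=C(CS/C(=N\C2CCCC2)NC2CCCC2)N2CCN=C2S1`: 3840 nM
Compound 2 `C1=C(CS/C(=N\C2CCCCC2)NC2CCCCCC2)N2CCN=C2S1`: 28 nM
Compound 3 `C1=C(CS/C(=N\C2CCCCC2)NC2CCCCCCC2)N2CCN=C2S1`: 28 nM

In an assay on CCRF-CEM cells for displacement of a labelled ligand from C-X-C chemokine receptor type 4 (Homo sapiens) (on this read-out higher numbers stand for weaker inhibition and lower numbers for stronger inhibition), compound 3 sits level with compound 2, and the two together give the lowest numbers of the three, while compound 1 lies far higher. Compound 4 `C1=C(CS/C(=N\C2CCCCC2)NC2CCCC2)N2CCN=C2S1` carries cyclopentyl in place of cyclooctyl on an amine nitrogen. Going by the values given here, the one single-point step measured here, no change at the digits printed from compound 2 to compound 3 (within the scatter), shows that adding a ring carbon changed nothing. Removing three is a different move, and compound 1, which carries cyclopentyl on both nitrogens, gives a much higher number than compound 3, though it differs in two places. A step toward weaker binding, a 13-fold higher number from compound 3 to compound 4 (1.10 log units; beyond the scatter), is therefore expected, with wide uncertainty. For compound 4 the expected value in this assay is 350 nM, between 60 nM and 2500 nM.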

Compound 4, half-maximal inhibitory concentration: 372 nM
The estimate for compound 4 lay 1.1-fold (0.03 log units) below the measured number, and the stated range covers the measured number.
By their numbers in this assay, from the lowest: compounds 2 and 3 (each within the scatter of the next); then compound 4; then compound 1.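

In this assay, cyclopentyl on an amine nitrogen gives a 13-fold higher number from compound 3 to compound 4 (1.12 log units; beyond the scatter) and a 13-fold higher number from compound 2 to compound 4 (1.12 log units; beyond the scatter), so ring size at this place does matter, even though cycloheptyl and cyclooctyl read alike. The double-bonded nitrogen counts as well: cyclohexyl in place of cyclopentyl there gives a 10-fold lower number from compound 1 to compound 4 (1.01 log units; beyond the scatter).

Still open, as far as these compounds go, is where between cyclopentyl and cycloheptyl the number falls, which cyclohexyl on the amine nitrogen would help settle, and whether an open chain such as hexyl serves as well as a ring. Nothing available here explains why ring size counts at either nitrogen.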